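The compounds below may be only part of what the source reports. "The series", "measured", "known", "first", "only" and "open" are said of these compounds alone.

Measured so far:
compound 1 `Cc1cc(C)n2nc(C)c(S(=O)(=O)c3ccccc3)c2n1` — 88.8 nM
compound 2 `Cc1cc(C)n2nc(NCCN(C)C)c(S(=O)(=O)c3ccccc3)c2n1` — 2600 nM

In a functional assay on HEK293 cells for antagonist activity at 5-hydroxytryptamine receptor 6 (Homo sapiens), read by cAMP accumulation, with a stated time of 2 h (a lower number here means a stronger inhibitor, a higher number a weaker inhibitor), compound 2 gives 2600 nM, the higher of the two numbers; compound 1 gives 88.8 nM. Among the measured compounds shown here, the only measured step is a 29-fold higher number from compound 1 to compound 2 (1.47 log units; beyond the scatter).

Compound 3 `Cc1cc(C)n2nc(NCCCN(C)C)c(S(=O)(=O)c3ccccc3)c2n1` differs from compound 2 by (dimethylamino)methyl in place of dimethylamino on a saturated chain carbon, two bonds along the chain from a nitrogen on an aromatic ring. For the measured compounds named here, no measured step alters the length of this chain; the one step on record concerns the presence of the whole aminoalkylamino group, not its length, so it gives no direction for compound 3. The expected step is therefore none beyond the scatter, a 1.0-fold lower number from compound 2 to compound 3 (0.02 log units; within the scatter). For compound 3 the estimate in this assay is 2500 nM, expected range 900 nM to 7000 nM.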

Compound 3, inhibition constant: 764 nM
For compound 3 the middle estimate is 3.3-fold (0.51 log units) above the measured one, outside the stated range (below it).
By their numbers in this assay, from the lowest: compound 1; then compound 3; then compound 2.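

Chain length at this position counts in this assay: going from (2-(dimethylamino)ethyl)amino to (3-(dimethylamino)propyl)amino gives a 3.4-fold lower number from compound 2 to compound 3 (0.53 log units; beyond the scatter) and so the two side chains are not interchangeable. The longer chain wins back only part of the loss from replacing methyl on the aromatic carbon, with an 8.6-fold higher number from compound 1 to compound 3 (0.93 log units; beyond the scatter) still remaining. No evidence bears on the origin of this chain-length effect.

Open, going by these compounds, is whether a longer chain, such as 4-(dimethylamino)butyl, moves the number further in the same direction. Also open, on these data alone, is whether a piperidine in place of dimethylamino at the chain end holds the gain.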